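The source may report more compounds than this note shows. Statements on the series, on what has been measured and on what is new or still open speak of the compounds shown alone.

Measured so far:
- compound 1 `COc1ccc(Cl)cc1C(=O)NCCC1CCN(S(=O)(=O)NC(=O)NC2CCCCC2)CC1` — 25%
- compound 2 `O=C(NC1CCCCC1)NS(=O)(=O)N1CCC(CCNC(=O)C(F)(F)F)CC1` — 13%
- compound 3 `O=C(NC[C@@H]1C[C@@H]2C=C[C@@H]1C2)NS(=O)(=O)N1CCC(CCNC(=O)C(F)(F)F)CC1` — 22%

In a functional assay on the whole organism (blood) with Rattus norvegicus as the target, with stated times of 24 h and 1 h, at a dose of 5 mg/kg by the intraperitoneal route (a lower number here means a weaker effect, a higher number a stronger effect of the compound at the dose given), compound 2 stands lowest of the three numbers; its nearest neighbour is compound 3, and the step of a number 9 percentage points higher from compound 2 to compound 3 (within the scatter) lies within the scatter, while the step of a number 12 percentage points lower from compound 1 to compound 2 (beyond the scatter) lies beyond it.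

Compound 4 `O=C(NC1CCCCC1)NS(=O)(=O)N1CCC(CCNC(=O)c2cscn2)CC1` is compound 2 with a change on the carbonyl carbon whose other neighbour is the amide-type nitrogen: 1,3-thiazol-4-yl in place of trifluoromethyl on a carbonyl carbon.

Among the measured compounds shown here, only one measured step touches this carbonyl carbon: a number 12 percentage points lower from compound 1 to compound 2 (beyond the scatter), where trifluoromethyl replaced 5-chloro-2-methoxyphenyl and the number fell by a modest amount. Compound 4 puts an aromatic ring back at that position, though a smaller one with two hetero atoms, so the expectation is a return toward the number of compound 1 rather than a further fall. The step of a number 9 percentage points higher from compound 2 to compound 3 (within the scatter) concerns a different part of the molecule and does not bear on this change.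

Compound 4 is therefore expected to give 22% in this assay, with a range of 10% to 34%, corresponding to an expected step of a number 9 percentage points higher from compound 2 to compound 4 (within the scatter).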

Compound 4, a percentage reported as activity, at one dose (the size of the read-out at that dose, not a potency): 23%
The estimate for compound 4 lay 1 percentage points below the measured number, and the stated range covers the measured number.
By their numbers in this assay, from the lowest: compounds 2, 3, 4 and 1 (each within the scatter of the next, the first and the last beyond it).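

In this assay, 1,3-thiazol-4-yl in place of trifluoromethyl on this carbonyl carbon gives a number 10 percentage points higher from compound 2 to compound 4 (within the scatter), and in place of 5-chloro-2-methoxyphenyl it gives a number 2 percentage points lower from compound 1 to compound 4 (within the scatter). Compound 4 therefore lies within the scatter of both compound 1 and compound 2, although those two lie beyond the scatter of each other, so it cannot be grouped with either one. The position accepts a five-membered aromatic ring with two hetero atoms without a readable difference from the substituted phenyl of compound 1, and no supporting data are available to explain this result.

On these data alone, it remains open whether an unsubstituted phenyl, a pyridin-3-yl or an open-chain tert-butyl on this carbonyl carbon would read closer to compound 1 or compound 2. As far as these compounds go, it is also open whether 1,3-thiazol-4-yl keeps its reading when the cyclohexyl group of compound 4 is replaced by the bridged ring group of compound 3.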